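Pyridin-4-yl for 4-Fluorophenyl on a Sparingly Soluble Core

The compounds below may be only part of what the source reports. "The series", "measured", "known", "first", "only" and "open" are said of these compounds alone.

Compound 1 `COC(=O)c1nc(C)c2c(c1N)C(=O)N(Cc1ccccc1)C2=O` gives 7400 nM in a physicochemical assay for solubility, using the shake flask method, in simulated intestinal fluid, measured as kinetic solubility, with a stated time of 2 h, at 25 degrees C, at pH 6.5; on this read-out lower numbers stand for lower solubility and higher numbers for higher solubility. Compound 2 `CCCOC(=O)c1nc(C)c2c(c1N)C(=O)N(Cc1ccccc1)C2=O` gives < 5000 nM in this assay, which is a limit. Compound 3 `Cc1noc(-c2nc(C)c3c(c2N)C(=O)N(Cc2ccc(F)cc2)C3=O)n1` gives < 5000 nM in this assay, likewise a limit.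

Compound 3 therefore stands only at a limit, namely (the limit of < 5000 nM in this assay, at which 2 of the 3 values shown sit). Compound 4 `Cc1noc(-c2nc(C)c3c(c2N)C(=O)N(Cc2ccncc2)C3=O)n1` differs from it by pyridin-4-yl in place of 4-fluorophenyl on a saturated chain carbon bound to an amide-type nitrogen in a ring. Among the measured compounds shown here, the single measured step, an at least 1.4-fold lower number from compound 1 to compound 2 (0.17 log units; that floor lies within the scatter), sits at another place of the shared core and does not bear on this change; no measured step does. The expectation for compound 4 thus rests on the limit of compound 3 alone, and a step of an at least 1.6-fold higher number from compound 3 to compound 4 (0.20 log units; that floor lies within the scatter) is expected, modest and uncertain. Compound 4 is estimated at 8000 nM, ranging from 3000 nM to 25000 nM.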

Compound 4, solubility: 26400 nM
Estimate against measurement, compound 4: 3.3-fold (0.52 log units) below; the measured number lies above the stated range.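

At the saturated chain carbon bound to an amide-type nitrogen in a ring, pyridin-4-yl in place of 4-fluorophenyl gives, in this assay, an at least 5.2-fold higher number from compound 3 to compound 4 (0.72 log units; beyond the scatter). This place, which the earlier step did not touch, can therefore move the number beyond the scatter. The step is only a floor, since compound 3 rests at a limit: the limit of < 5000 nM in this assay, at which 2 of the 4 values shown sit.

The compounds shown do not separate the effect of gaining the ring nitrogen from that of losing the fluorine. On these data alone, whether pyridin-3-yl or an amine-bearing chain at this place would give a similar step remains open.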